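Amide aryl variation on the hexafluoro-carbinol naphthylamine core

A few compounds are considered here, and "the series" means these few. Any claim that something is new, unique, unknown or untested is made for them only; others in the source may bear on it.

Three amides of the shared core have been measured. Compound 1 `C/C=C/C(=O)Nc1c(C(O)(C(F)(F)F)C(F)(F)F)ccc2ccccc12` gives 72 nM in an assay on LtK cells with ATP-sensitive inward rectifier potassium channel 11 (Homo sapiens) as the target; a higher number here means that more compound is needed for the effect, a lower number that less compound is needed. Compound 2 `O=C(Nc1c(C(O)(C(F)(F)F)C(F)(F)F)ccc2ccccc12)c1cccc(Br)c1` gives 80 nM, and the step of a 1.1-fold higher number from compound 1 to compound 2 (0.05 log units; within the scatter) sits within the scatter. Compound 3 `Cc1cccc(C(=O)Nc2c(C(O)(C(F)(F)F)C(F)(F)F)ccc3ccccc23)c1` gives 23 nM, the lowest of the three numbers; its separation from the others is beyond the scatter, as seen in a 3.1-fold lower number from compound 1 to compound 3 (0.50 log units; beyond the scatter) and in a 3.5-fold lower number from compound 2 to compound 3 (0.54 log units; beyond the scatter).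

Compound 4 `O=C(Nc1c(C(O)(C(F)(F)F)C(F)(F)F)ccc2ccccc12)c1cc(Cl)cc(Cl)c1` is not yet measured. The change from compound 3 is 3,5-dichlorophenyl in place of 3-methylphenyl on a carbonyl carbon.

For the measured compounds named here, the only measured step that bears on this change is the one between compound 2 and compound 3, where methyl in place of bromo on an aromatic carbon gave a 3.5-fold lower number from compound 2 to compound 3 (0.54 log units; beyond the scatter). Read in the reverse direction, a halogen in place of the methyl would be expected to raise the number by a modest amount. Going by the values given here, no measured pair shows the effect of a second chloro on the ring, so the added substituent is an unknown; the estimate stays close to the compound 2 region, with a wide range.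

For compound 4 a step of a 3.0-fold higher number from compound 3 to compound 4 (0.48 log units; beyond the scatter) is expected, giving an estimated 70 nM with a range from 30 nM to 170 nM.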

Compound 4, half-maximal effective concentration: 306 nM
Estimate against measurement, compound 4: 4.4-fold (0.64 log units) below, and the stated range ends below it.
By their numbers in this assay, from the lowest: compound 3; then compounds 1 and 2 (each within the scatter of the next); then compound 4.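

In this assay, for the compounds shown here, the aryl group on the carbonyl carbon proves sensitive to substitution: swapping 3-methylphenyl for 3,5-dichlorophenyl gives a 13-fold higher number from compound 3 to compound 4 (1.12 log units; beyond the scatter) and is the only large step, where earlier steps were modest or within the scatter. The 3,5-dichlorophenyl amide also separates from the two amides that could not be told apart, with a 3.8-fold higher number from compound 2 to compound 4 (0.58 log units; beyond the scatter) against the 3-bromophenyl group and a 4.3-fold higher number from compound 1 to compound 4 (0.63 log units; beyond the scatter) against the prop-1-en-1-yl group, so the range of numbers at this position is wider than the first three compounds showed. Nothing on hand explains this rise, and it stands as an observation only.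

It remains open whether the rise belongs to the second chlorine or to chlorine in place of methyl, as neither a 3-chlorophenyl nor a 3,5-dimethylphenyl amide stands among these compounds. Also open, going by these compounds, is how an amine or a carboxylic acid on the aryl ring, or a longer chain in place of prop-1-en-1-yl, would compare with the 3-methylphenyl group of compound 3.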